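Swapping Butyl for Cyanomethoxy on a Dichlorinated Core

The compounds below may be only part of what the source reports. "The series", "measured", "known", "first", "only" and "open" are said of these compounds alone.

Of the compounds shown here, three built on one shared core have so far been measured in a physicochemical assay for lipophilicity, measured as octanol-water partition; on this read-out higher numbers stand for higher lipophilicity and lower numbers for lower lipophilicity. Compound 1 `CCO/N=C/Nc1cc(Cl)c(CC)c(Cl)c1` gives 4.8. Compound 2 `CCCCc1c(Cl)cc(N/C=N/OCC)cc1Cl` gives 5.6, and the step between them, a number 0.80 log units higher from compound 1 to compound 2 (beyond the scatter), comes from putting an ethyl in place of hydrogen on a saturated chain carbon, two bonds along the chain from an aromatic carbon. Compound 3 `CCO/N=C/Nc1cc(Cl)c(S(=O)(=O)CC)c(Cl)c1` gives 2.8. Compound 2 thus stands highest of the three: its nearest neighbour is compound 1, separated by a number 0.80 log units higher from compound 1 to compound 2 (beyond the scatter), and its furthest is compound 3, separated by a number 2.80 log units lower from compound 2 to compound 3 (beyond the scatter).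

Compound 4 `CCO/N=C/Nc1cc(Cl)c(OCC#N)c(Cl)c1` has not yet been measured. Its difference from compound 2 is cyanomethoxy in place of butyl on an aromatic carbon. For the measured compounds named here, the steps that bear on this change are a number 2.00 log units lower from compound 1 to compound 3 (beyond the scatter) and a number 2.80 log units lower from compound 2 to compound 3 (beyond the scatter), in which an ethylsulfonyl, a group with several hydrogen-bond acceptors, took the place of a carbon-only chain and lowered the read-out by a large amount each time. Cyanomethoxy likewise brings two hydrogen-bond acceptors in place of a carbon-only butyl, so a large downward step is expected here too. The estimated step is a number 2.20 log units lower from compound 2 to compound 4 (beyond the scatter). Compound 4 is therefore expected to give about 3.4, within a range from 2.9 to 3.9.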

Compound 4, partition coefficient: 3.1
Beside the measured number, compound 4's estimate is 0.30 log units above it, within the range that was stated.
By their numbers in this assay, from the lowest: compounds 3 and 4 (each within the scatter of the next); then compound 1; then compound 2.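

Butyl and cyanomethoxy each hold 4 heavy atoms, so this swap changes the kind of atoms at this position on the aromatic carbon and not their number, and in this assay the result is a number 2.50 log units lower from compound 2 to compound 4 (beyond the scatter) and, against the shorter ethyl group, a number 1.70 log units lower from compound 1 to compound 4 (beyond the scatter) as well. Until now only ethylsulfonyl had shown a drop of this kind here, but the new comparison with it gives a number 0.30 log units higher from compound 3 to compound 4 (within the scatter) so these two different groups cannot be ranked on this read-out, and a large drop at this position is no longer tied to a single group. Nothing measured here explains why the number falls with either group.

The compounds shown leave open where a plain ethoxy group would fall at this position, which would separate the share of the oxygen from that of the nitrile in cyanomethoxy. Also open, going by these compounds, is how an amine or a carboxylic acid would compare here, and whether a swap from butyl to cyanomethoxy gives a step of similar size on a core without the two chloro groups.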